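The source may hold more compounds than are shown below. What is called first, only, known or untested is meant among the compounds shown, and "the series" means these compounds.

Measured compounds:
- Compound 1, `COc1ccc(-c2cc(/C=C/C(=O)c3ccc(N)cc3)[nH]n2)cc1`: 45%
- Compound 2, `COc1cc(-c2cc(/C=C/C(=O)c3ccc(Cl)c(Cl)c3)[nH]n2)cc(OC)c1OC`: 23%

Of the compounds shown here, two share a core and have been tested in a functional assay on SR cells (Homo sapiens) for cytotoxicity, read by sulforhodamine B assay, with a stated time of 48 h, tested at 1 uM; a lower number here means a stronger effect, a higher number a weaker effect of the compound at the concentration tested. Compound 1 gives 45% in this assay, and compound 2 gives 23%. Of the two numbers, compound 1 stands highest, which in this assay means the weaker effect of the pair; compound 2 sits lower by a margin beyond the usual scatter. Within the data shown here, the two structures differ in several places at once, so no single step between them can be read off.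

Compound 3, `COc1ccc(-c2cc(/C=C/C(=O)c3ccc(N)cc3)[nH]n2)cc1OC`, is not yet measured. It is built from compound 1 by one change: methoxy in place of hydrogen on an aromatic carbon. Among the measured compounds shown here, no measured pair shows this change on its own, so nothing in the data fixes its size. With only the two numbers above to go on, a small step in this assay is expected, if any, with the number for compound 3 drifting somewhat lower than that of compound 1, but the step from compound 1 to compound 3, a number 7 percentage points lower from compound 1 to compound 3 (within the scatter), is expected to stay near the scatter. Compound 3 is therefore estimated at 38%, within a range from 20% to 60%.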

Compound 3, a percentage reported as activity, at one concentration (the size of the read-out at that concentration, not a potency): 34%
The estimate for compound 3 lay 4 percentage points above the measured number, within the range that was stated.
By their numbers in this assay, from the lowest: compound 2; then compound 3; then compound 1.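

Read in this assay, this is the first single change in the set whose size can be seen on its own: methoxy in place of hydrogen gives a number 11 percentage points lower from compound 1 to compound 3 (beyond the scatter). Since a lower number means a stronger effect, an aromatic carbon ortho to a methoxy group and meta to a large group can carry a second methoxy group, and the compound gains modestly in effect at the concentration tested. Nothing in the data at hand explains why this step has the size it has.

The compounds shown leave open whether another group on this same carbon, such as a hydroxyl group, an ethoxy group or a chlorine atom, would move the number further, or in the other direction. They also leave open whether the added methoxy group would give a step of similar size on a compound in which a different group, such as a dimethylamino group, takes the place of the amino group found in compound 1 and compound 3.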